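Removing an amine methyl on a clearance series

A few compounds are considered here, and "the series" means these few. Any claim that something is new, unique, unknown or untested is made for them only; others in the source may bear on it.

Three compounds sharing one core have been run in an ADME assay on cells (Hepatocyte, Rattus norvegicus) for metabolic stability; on this read-out lower numbers stand for slow clearance and higher numbers for fast clearance. Compound 1 `Cc1ccc2[nH]c(C(=O)N[C@H]3CN(S(=O)(=O)c4ccccc4)C[C@@H]3C(=O)NCCN(C)C)cc2c1` gives 16 uL/min. Compound 2 `Cc1ccc2[nH]c(C(=O)N[C@H]3CN(S(=O)(=O)c4ccccc4)C[C@@H]3C(=O)NC[C@H]3CCCN3C)cc2c1` gives 21 uL/min, and compound 3 `Cc1ccc2[nH]c(C(=O)N[C@H]3CN(S(=O)(=O)c4ccccc4)C[C@@H]3C(=O)N[C@@H]3CCCN(C)C3)cc2c1` gives 23 uL/min. The steps of a 1.3-fold higher number from compound 1 to compound 2 (0.12 log units; within the scatter), a 1.4-fold higher number from compound 1 to compound 3 (0.16 log units; within the scatter) and a 1.1-fold higher number from compound 2 to compound 3 (0.04 log units; within the scatter) all stay within the scatter, so the three numbers cannot be told apart. Compound 4 `Cc1ccc2[nH]c(C(=O)N[C@H]3CN(S(=O)(=O)c4ccccc4)C[C@@H]3C(=O)N[C@@H]3CCCNC3)cc2c1` differs from compound 3 by hydrogen in place of methyl on an amine nitrogen in a ring. No shown step removes a methyl from an amine nitrogen in a ring; the steps that reshaped the amine-bearing group were all within the scatter. The step of a 1.2-fold lower number from compound 3 to compound 4 (0.06 log units; within the scatter) is therefore expected to stay within the scatter. Compound 4 is estimated at 20 uL/min, between 10 uL/min and 42 uL/min.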

Compound 4, intrinsic clearance in a liver preparation (reported as CLH), per the amount of preparation that the assay uses: 9 uL/min
For compound 4 the middle estimate is 2.2-fold (0.35 log units) above the measured one, outside the stated range (below it).
By their numbers in this assay, from the lowest: compounds 4, 1, 2 and 3 (each within the scatter of the next, the first and the last beyond it).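

In this assay, within the data shown here, the step of a 2.6-fold lower number from compound 3 to compound 4 (0.41 log units; beyond the scatter) is the first single change on the amine in this set to pass beyond the scatter, and it is the ring amine nitrogen that carries it. The piperidin-3-yl amide also separates from one earlier amide in the step of a 2.3-fold lower number from compound 2 to compound 4 (0.37 log units; beyond the scatter) but not from the other in the step of a 1.8-fold lower number from compound 1 to compound 4 (0.25 log units; within the scatter), so the effect does not reach all of the amine-bearing groups. Nothing at hand accounts for this change. As far as these compounds go, whether an ethyl or acetyl group on this ring nitrogen would read like hydrogen or like methyl remains open, as does whether removing a methyl from the amines of compound 1 and compound 2 would do the same.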